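A few compounds are considered here, and "the series" means these few. Any claim that something is new, unique, unknown or untested is made for them only; others in the source may bear on it.

Measured so far in a functional assay on the whole organism with Mus musculus as the target; a lower number here means that less compound is needed, a higher number that more compound is needed for the effect:
Compound 1 `C[C@@H](NCc1ccc(Oc2ccccc2)cc1)C(N)=O`: 64 mg/kg
Compound 2 `C[C@@H](NCc1ccc(OCc2cccs2)cc1)C(N)=O`: 61.6 mg/kg

For the measured compounds named here, compound 2 stands level with the only other measured compound, since the step of a 1.0-fold lower number from compound 1 to compound 2 (0.02 log units; within the scatter) lies within the scatter. Compound 3 `C[C@@H](NCc1ccc(OCc2ccsc2)cc1)C(N)=O` has the same atoms as compound 2, joined differently, with thiophen-3-yl in place of thiophen-2-yl on a saturated chain carbon bound to an oxygen on an aromatic ring. Going by the values given here, no measured pair tests this exact swap. The nearest evidence is the step of a 1.0-fold lower number from compound 1 to compound 2 (0.02 log units; within the scatter), in which (thiophen-2-yl)methyl replaced phenyl on the oxygen and the number stayed within the scatter. On that single step, no change beyond the scatter is expected in this assay. The expected step is a 1.0-fold lower number from compound 2 to compound 3 (0.01 log units; within the scatter). For compound 3 the estimated value is 60 mg/kg, with an expected range of 32 mg/kg to 110 mg/kg.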

Compound 3, dose for half-maximal effect: 114 mg/kg
For compound 3 the middle estimate is 1.9-fold (0.28 log units) below the measured one; the measured number lies above the stated range.
By their numbers in this assay, from the lowest: compounds 2, 1 and 3 (each within the scatter of the next).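

In this assay, thiophen-3-yl in place of thiophen-2-yl on a saturated chain carbon bound to an oxygen on an aromatic ring gives a 1.9-fold higher number from compound 2 to compound 3 (0.27 log units; within the scatter), so this swap of two groups with the same atoms does not separate them. The wider replacement, (thiophen-3-yl)methyl in place of phenyl on the oxygen, gives a 1.8-fold higher number from compound 1 to compound 3 (0.25 log units; within the scatter), which places all three compounds within the scatter of one another. Nothing available explains the size of either step.

Still open, on these data alone, is whether a pyridine ring or a longer chain on that oxygen would move the number beyond the scatter. Also open, as far as these compounds go, is whether a carboxylic acid in place of the amide of the shared core would do so.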